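Ethyl for cyclobutyl on the core of compound 2

The source may report more compounds than this note shows. Statements on the series, on what has been measured and on what is new or still open speak of the compounds shown alone.

Among the measured compounds shown here, compound 1 `CCCc1ccc(/C=C/C(=O)Nc2ccc3nc(CCC)cc(N)c3c2)cc1` gives 3600 nM in a functional assay on HEK293 cells for activation of melanin-concentrating hormone receptor 1 (Homo sapiens), read by inositol phosphate accumulation (a lower number here means that less compound is needed, a higher number that more compound is needed for the effect), and compound 3 `CCCCc1ccc(/C=C/C(=O)Nc2ccc3nc(CCC)cc(N)c3c2)cc1` gives 740 nM; the step of a 4.9-fold lower number from compound 1 to compound 3 (0.69 log units; beyond the scatter) is the only single-point change measured. Compound 2 `Nc1cc(C2CCC2)nc2ccc(NC(=O)/C=C/c3ccc(C(F)(F)F)cc3)cc12` gives 250 nM, the lowest of the three numbers; its gaps to compound 3 and to compound 1 are both beyond the scatter. Compound 4 `CCc1cc(N)c2cc(NC(=O)/C=C/c3ccc(C(F)(F)F)cc3)ccc2n1` differs from compound 2 by ethyl in place of cyclobutyl on an aromatic carbon. For the measured compounds named here, no measured step touches that position; the step from compound 1 to compound 3 concerns the other end of the molecule, so it gives no direct guide. Compound 2 is expected to lose somewhat on this change, the step of a 2.4-fold higher number from compound 2 to compound 4 (0.38 log units; beyond the scatter) being estimated as small, toward a higher number. Compound 4 is thus estimated at 600 nM, within 200 nM to 2000 nM.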

Compound 4, half-maximal effective concentration: 110 nM
Compound 4: the middle estimate sits 5.5-fold (0.74 log units) above what was measured, and the stated range ends above it.
By their numbers in this assay, from the lowest: compound 4; then compound 2; then compound 3; then compound 1.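

In this assay, among the compounds shown here, the change of cyclobutyl to ethyl on the aromatic carbon next to the ring nitrogen gives a 2.3-fold lower number from compound 2 to compound 4 (0.36 log units; beyond the scatter) and is the first measured step at this position. The four-membered ring is therefore not required for activity in this pair, and the open ethyl group gives the lower number by a margin beyond the scatter. No evidence on hand accounts for this step.

Still open, going by these compounds, is whether methyl or an amine on this carbon would lower the number further. Also open, on these data alone, is whether the ethyl-for-cyclobutyl step holds when trifluoromethyl is replaced by another group.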